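Replacing a biaryl group on a shared core

The source may report more compounds than this note shows. Statements on the series, on what has been measured and on what is new or still open speak of the compounds shown alone.

- compound 1 `NC1CCC(Nc2nc(NCc3ccc(-c4ccco4)cc3)c3ncn(C4CCCC4)c3n2)CC1` gives 102 nM in a functional assay on HOS cells (Homo sapiens) for inhibition, with a stated time of 72 h; a lower number here means a stronger inhibitor, a higher number a weaker inhibitor
- compound 2 `NC1CCC(Nc2nc(NCc3ccc(-n4cccn4)cc3)c3ncn(C4CCCC4)c3n2)CC1` gives 103 nM in this assay

For the measured compounds named here, compound 1 stands level with compound 2, its only measured neighbour, and the two do not separate: the step is a 1.0-fold higher number from compound 1 to compound 2 (0.00 log units; within the scatter) with 1H-pyrazol-1-yl in place of furan-2-yl. Compound 3 `NC1CCC(Nc2nc(NCc3ccc(-c4ccsc4)nc3)c3ncn(C4CCCC4)c3n2)CC1` differs from compound 1 by 6-(thiophen-3-yl)pyridin-3-yl in place of 4-(furan-2-yl)phenyl on a saturated chain carbon bound to a nitrogen on an aromatic ring in the group named there. That one measured step bears only on the furan-2-yl part of this change, and no measurement covers the 6-(thiophen-3-yl)pyridin-3-yl group. Expected in this assay is a 1.3-fold higher number from compound 1 to compound 3 (0.11 log units; within the scatter) and thus no step beyond the scatter. The estimated value for compound 3 is 130 nM (from 45 nM to 380 nM).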

Compound 3, half-maximal inhibitory concentration: 89 nM
Beside the measured number, compound 3's estimate is 1.5-fold (0.16 log units) above it; measured number inside the range.
By their numbers in this assay, from the lowest: compounds 3, 1 and 2 (each within the scatter of the next).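

With a 1.1-fold lower number from compound 1 to compound 3 (0.06 log units; within the scatter) and a 1.2-fold lower number from compound 2 to compound 3 (0.06 log units; within the scatter) in this assay the two earlier groups and 6-(thiophen-3-yl)pyridin-3-yl do not separate. The earlier pair changed only the five-membered aromatic ring, whereas here both aromatic rings of the group change and the numbers still stay within the scatter. Nothing available explains this level result.

Going by these compounds, whether thiophen-3-yl alone or the pyridin-3-yl ring alone would give the same number stays open. So does the outcome of a plain phenyl group, or of an amine or a carboxylic acid on the six-membered ring in place of the five-membered one.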